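The source may report more compounds than this note shows. Statements on the series, on what has been measured and on what is new or still open speak of the compounds shown alone.

Compound 1 `CCOC(=O)N1CCC(=NNC(=O)c2ccc(C(F)(F)F)cc2)CC1`: in a functional assay, read by spectrophotometry, with a stated time of 2 h (on this read-out lower numbers stand for stronger inhibition and higher numbers for weaker inhibition), compound 1 gives 33800 nM.
Compound 2 `O=C(NN=C1CC(c2ccccc2)NC(c2ccccc2)C1)c1ccc(Cl)cc1`: in this assay compound 2 gives 96700 nM.

Of these two numbers, compound 2 has the higher one, and its gap from compound 1 is beyond the usual scatter, so compound 2 is the weaker inhibitor of the pair. Within the data shown here, compound 3 `O=C(NN=C1CC(c2ccccc2)NC(c2ccccc2)C1)c1ccc([N+](=O)[O-])cc1` keeps the whole core of compound 2 and changes only one group: nitro in place of chloro on an aromatic carbon, in words nitro in place of chloro on an aromatic carbon. Among the measured compounds shown here, no measured pair shows this particular change, so there is no step to lean on. The change is expected to move this assay little, by a 1.2-fold lower number from compound 2 to compound 3 (0.08 log units; within the scatter), in no direction beyond the scatter. Compound 3 is therefore estimated at 80000 nM, in the range 25000 nM to 250000 nM.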

Compound 3, half-maximal inhibitory concentration: 88100 nM
Compound 3: the middle estimate sits 1.1-fold (0.04 log units) below what was measured, and the stated range covers the measured number.
By their numbers in this assay, from the lowest: compound 1; then compounds 3 and 2 (each within the scatter of the next).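

Nitro in place of chloro on the aromatic ring gives a 1.1-fold lower number from compound 2 to compound 3 (0.04 log units; within the scatter) in this assay, the first comparison here that differs in only one place. Compound 2 and compound 3 cannot be told apart at this position, even though the entering group has more heavy atoms and brings hydrogen-bond acceptors. Nothing available here explains this result. On these data alone, it remains open how an amine or a carboxylic acid in this same place would read, since one pair cannot show how other groups behave there.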